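A few compounds are considered here, and "the series" means these few. Any claim that something is new, unique, unknown or untested is made for them only; others in the source may bear on it.

In a functional assay (strain AB) with Danio rerio as the target, read by microscopy, with a stated time of 1 h (on this read-out lower numbers stand for an effect already at smaller amounts and higher numbers for an effect only at larger amounts of compound), compound 1 `CCN1CCc2c(sc(NC(=O)Nc3ccc(Cl)cc3)c2C(N)=O)C1` gives 3120 nM. Compound 2 `CCN1CCc2c(sc(NC(=O)Nc3ccc(Cl)cc3)c2C(=O)O)C1`, which carries hydroxy in place of amino on a carbonyl carbon, gives > 25000 nM, and this is a limit of the assay and not a number. Compound 2 therefore stands at the limit of > 25000 nM in this assay, at which 1 of the 2 values shown sits, and no exact value can be placed on it.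

Compound 3 `CCN1CCc2c(sc(NC(=O)Nc3ccc(Cl)cc3)c2C(=O)c2nc(C)no2)C1` changes the same place: 3-methyl-1,2,4-oxadiazol-5-yl in place of hydroxy on a carbonyl carbon, (3-methyl-1,2,4-oxadiazol-5-yl in place of hydroxy on a carbonyl carbon). Going by the values given here, only one measured step bears on this change. That step, an at least 8.0-fold higher number from compound 1 to compound 2 (0.90 log units; beyond the scatter), brought hydroxy onto this carbonyl carbon. With hydroxy now leaving, a step of similar size toward a lower number is expected in this assay. Among the compounds with values here, the expectation is uncertain, since no measured step tests the entering group, and a second limit remains possible.

The estimate corresponds to an expected at least 5.0-fold lower number from compound 2 to compound 3 (0.69 log units; beyond the scatter). For compound 3 the estimated value is 5000 nM, with an expected range of 1200 nM to 20000 nM.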

Compound 3, half-maximal effective concentration: > 25000 nM
Compound 3: only a limit was reported; the forecaster's own chance of this, stated with the estimate: 25%; middle value at least 5.0-fold (0.69 log units) from the limit.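

Swapping amino on this carbonyl carbon for 3-methyl-1,2,4-oxadiazol-5-yl gives an at least 8.0-fold higher number from compound 1 to compound 3 (0.90 log units; beyond the scatter), so this is the second replacement at this place that ends in a step of this kind, after an at least 8.0-fold higher number from compound 1 to compound 2 (0.90 log units; beyond the scatter). Of the three compounds shown, only compound 1, with amino, gives a number rather than a limit, and the larger ring-bearing group does no better here than hydroxy as far as this assay can tell. The step between hydroxy and 3-methyl-1,2,4-oxadiazol-5-yl cannot be read, and compound 3 adds a second entry at the same limit of the assay, which is a limit and not a number: the limit of > 25000 nM in this assay, at which 2 of the 3 values shown sit.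

Going by these compounds alone, whether amino is the only group on this carbonyl carbon that keeps a measurable value stays open, and a methylamino or a methoxy group in its place would show how narrow that requirement is. As far as these compounds go, how far either limit compound lies beyond the limit also remains unknown, so hydroxy and 3-methyl-1,2,4-oxadiazol-5-yl cannot be put in any order.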